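Nitro to methoxy: working notes on the series

The source may report more compounds than this note shows. Statements on the series, on what has been measured and on what is new or still open speak of the compounds shown alone.

In a functional assay on U-251 cells (Homo sapiens) for inhibition, read by MTT assay, with a stated time of 2 days (a higher number here means a weaker inhibitor of growth, a lower number a stronger inhibitor of growth), compound 3 `Nc1ccccc1NC(=O)c1ccc(NCC(=O)Nc2ccc([N+](=O)[O-])cc2)cc1` gives 42500 nM. Compound 2 `Nc1ccccc1NC(=O)CCCNCC(=O)Nc1ccc(Cl)cc1` gives 75000 nM, and these two values lie within the scatter of each other. Compound 1 `Nc1ccccc1NC(=O)CCCNCC(=O)Nc1cccc(Cl)c1` gives > 100000 nM, which is a limit and not a number, so it stands at the limit of > 100000 nM in this assay, at which 1 of the 3 values shown sits.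

Compound 4 `COc1ccc(NC(=O)CNc2ccc(C(=O)Nc3ccccc3N)cc2)cc1` keeps the frame of compound 3 and carries methoxy in place of nitro on an aromatic carbon, para to a large group: methoxy in place of nitro on an aromatic carbon.

Within the data shown here, only one measured step is available as a guide, an at least 1.3-fold lower number from compound 1 to compound 2 (0.12 log units; that floor lies within the scatter). It moves a chlorine-bearing aryl group on a different frame, and its size is known only as a floor. Among the measured compounds shown here, no measured step exchanges nitro for methoxy, so its bearing on this change is indirect. With no measured step beyond the scatter, no step beyond the scatter is expected in this assay, and no firm direction can be assigned.

The expected step is a 1.2-fold higher number from compound 3 to compound 4 (0.07 log units; within the scatter). For compound 4 the estimated value is 50000 nM, with an expected range from 22000 nM to 100000 nM.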

Compound 4, concentration for total growth inhibition: > 100000 nM
Compound 4: no number, only a limit; the forecaster's own chance of this, stated with the estimate: 15%; middle value at least 2.0-fold (0.30 log units) from the limit.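

In this assay, methoxy in place of nitro on this aromatic carbon gives the only step shown that lies beyond the scatter: an at least 2.3-fold higher number from compound 3 to compound 4 (0.37 log units; beyond the scatter). Among these compounds, this position, para to a large group, therefore matters on the frame of compound 3, whereas the one earlier step, which moved a chlorine on a different frame, showed no change beyond the scatter. On these data alone, compound 4 gives only a limit of the assay, so the step is a floor and its full size remains unknown: the limit of > 100000 nM in this assay, at which 2 of the 4 values shown sit.

A single pair cannot separate the removal of nitro from the arrival of methoxy, and a nitrile, a trifluoromethyl group or plain hydrogen on the same aromatic carbon of this frame would be needed to show which of the two the step follows. As far as these compounds go, it also remains open whether the step carries over to the frame of compound 2, where a 4-nitrophenyl and a 4-methoxyphenyl group would give the matching pair on the chain-linked frame.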